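The source may hold more compounds than are shown below. What is called first, only, known or untested is meant among the compounds shown, and "the series" means these compounds.

In a functional assay on DU-145 cells (Homo sapiens) for inhibition, read by trypan blue exclusion, with a stated time of 96 h (a lower number here means a stronger inhibitor of growth, a higher number a weaker inhibitor of growth), compound 1 `O=C(/C(=C\c1ccc(O)c([N+](=O)[O-])c1)SCc1ccc(Br)cc1)c1c(F)c(F)c(F)c(F)c1F` gives 10000 nM, level with compound 3 `Cc1ccc(CS/C(=C/c2ccccc2F)C(=O)c2ccc(Cl)cc2)cc1` at 10000 nM. Compound 2 `O=C(/C(=C\c1ccc(O)c([N+](=O)[O-])c1)S(=O)(=O)Cc1ccc(Br)cc1)c1c(F)c(F)c(F)c(F)c1F` gives 50000 nM. Compound 4 `COc1ccc(C(=O)/C(=C\c2ccc(O)c([N+](=O)[O-])c2)SCc2ccc(Br)cc2)cc1` keeps the rest of compound 1 but has 4-methoxyphenyl in place of 2,3,4,5,6-pentafluorophenyl on a carbonyl carbon. Going by the values given here, the only measured single change, a 5.0-fold higher number from compound 1 to compound 2 (0.70 log units; beyond the scatter), is a modest step, but it swaps (4-bromobenzyl)sulfanyl for (4-bromobenzyl)sulfonyl and leaves the carbonyl side untouched. Among the compounds with values here, no measured pair isolates the group now being replaced, so no direction can be argued and a step within the scatter is the working expectation: no change at the digits printed from compound 1 to compound 4 (within the scatter). For compound 4 the estimated value is 10000 nM, with an expected range of 2500 nM to 40000 nM.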

Compound 4, concentration for 50% growth inhibition: 10000 nM
Estimate against measurement, compound 4: no gap at the digits printed, and the stated range covers the measured number.
By their numbers in this assay, from the lowest: compounds 1, 3 and 4 (each within the scatter of the next); then compound 2.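

In this assay, going by these compounds alone, this is the first measured change on the carbonyl side of the shared core, and swapping 2,3,4,5,6-pentafluorophenyl for 4-methoxyphenyl on the carbonyl carbon leaves growth inhibition unmoved (no change at the digits printed from compound 1 to compound 4 (within the scatter)). This position therefore accepts either aromatic ring without a change beyond the scatter. Nothing available here explains why the two rings match. Still open, as far as these compounds go, is whether a different kind of group on this carbon, such as an amine or a carboxylic acid, would hold this level. Also open, from the compounds shown here alone, is whether the same swap would behave alike with the (4-bromobenzyl)sulfonyl group of compound 2.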